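Changing the Aryl Group on the Ring Nitrogen

A few compounds are considered here, and "the series" means these few. Any claim that something is new, unique, unknown or untested is made for them only; others in the source may bear on it.

Three compounds share one core and differ only in the aryl group attached to an amine nitrogen in a ring. In an assay on liver for binding affinity to Alpha-1D adrenergic receptor (Homo sapiens), using microsomes (a lower number here means a stronger inhibitor, a higher number a weaker inhibitor), compound 1 `COC(=O)C1=C(C)NC(=O)N(C(=O)NCCCN2CCN(c3ccccc3O)CC2)C1c1ccc(F)c(F)c1` gives 31 nM, and compound 2 `COC(=O)C1=C(C)NC(=O)N(C(=O)NCCCN2CCN(c3ccc(Cl)cc3)CC2)C1c1ccc(F)c(F)c1` gives 52 nM; the step of a 1.7-fold higher number from compound 1 to compound 2 (0.22 log units; within the scatter) separates them. Compound 3 `COC(=O)C1=C(C)NC(=O)N(C(=O)NCCCN2CCN(c3ccc(OC)cc3C)CC2)C1c1ccc(F)c(F)c1` gives 610 nM, the highest of the three numbers, and the steps of a 20-fold higher number from compound 1 to compound 3 (1.29 log units; beyond the scatter) and a 12-fold higher number from compound 2 to compound 3 (1.07 log units; beyond the scatter) both lie beyond the scatter, so compound 3 is the weakest inhibitor among the three measured.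

Compound 4 `COC(=O)C1=C(C)NC(=O)N(C(=O)NCCCN2CCN(c3ccccc3Cl)CC2)C1c1ccc(F)c(F)c1` has not yet been measured. The change is 2-chlorophenyl in place of 4-methoxy-2-methylphenyl on an amine nitrogen in a ring. The two steps that bear on it both run toward compound 3: the groups 2-hydroxyphenyl and 4-chlorophenyl each give a far lower number than 4-methoxy-2-methylphenyl, as a 20-fold higher number from compound 1 to compound 3 (1.29 log units; beyond the scatter) and a 12-fold higher number from compound 2 to compound 3 (1.07 log units; beyond the scatter) show. The entering 2-chlorophenyl carries a chlorine, as does the 4-chlorophenyl of compound 2, and, like the 2-hydroxyphenyl of compound 1, it carries a single small group. A large step back down is therefore expected, a 12-fold lower number from compound 3 to compound 4 (1.09 log units; beyond the scatter). Compound 4 is estimated to give 50 nM in this assay, with an expected range from 15 nM to 200 nM.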

Compound 4, inhibition constant: 14 nM
The estimate for compound 4 lay 3.6-fold (0.55 log units) above the measured number; measured number below the stated range.
By their numbers in this assay, from the lowest: compound 4; then compounds 1 and 2 (each within the scatter of the next); then compound 3.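

In this assay, 2-chlorophenyl gives the largest step yet seen at this amine nitrogen, a 44-fold lower number from compound 3 to compound 4 (1.64 log units; beyond the scatter), and compound 4 is now the strongest inhibitor of the four, with its steps to all the others beyond the scatter. The step of a 3.7-fold lower number from compound 2 to compound 4 (0.57 log units; beyond the scatter) shows that the two chlorine-bearing groups, 2-chlorophenyl and 4-chlorophenyl, are not equivalent here, so the place of the chlorine on the aromatic ring matters as well as its presence. The step of a 2.2-fold lower number from compound 1 to compound 4 (0.35 log units; beyond the scatter) shows that a hydroxy group is not needed for a low number, and that chloro gives a lower one than hydroxy when the two are exchanged on the same aromatic carbon.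

No measurement here explains why these changes shift the number. The compounds shown also leave open how other single groups in the place of this chlorine would compare, such as those in 2-fluorophenyl or 2-methoxyphenyl, and whether 2-methylphenyl alone would give a number close to that of compound 3 or to that of compound 4.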